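The compounds below may be only part of what the source reports. "The series", "measured", "known", "first", "only" and "open" are said of these compounds alone.

Measured in a functional assay on IGROV-1 cells (Homo sapiens) for inhibition, read by sulforhodamine B assay, with a stated time of 48 h; on this read-out lower numbers stand for higher toxicity in this test and higher numbers for lower toxicity in this test:
- compound 1 `COc1cc(-c2nn(-c3cccc(NC(=O)Nc4cc(C(F)(F)F)cc(C(F)(F)F)c4)c3)cc2-c2ccncc2)ccc1Cl`: 23700 nM
- compound 2 `COc1cc(-c2nn(-c3cccc(NC(=O)c4cccc(C(F)(F)F)c4)c3)cc2-c2ccncc2)ccc1Cl`: > 50000 nM

Compound 2 stands at > 50000 nM, which is a limit of this assay and not a number. Within the data shown here, the series so far therefore holds (the limit of > 50000 nM in this assay, at which 1 of the 2 values shown sits). Only compound 1 has a number, 23700 nM.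

Compound 3 `COc1cc(-c2nn(-c3cccc(NC(=O)c4ccc(Cl)c(C(F)(F)F)c4)c3)cc2-c2ccncc2)ccc1Cl` keeps the core of compound 2 and changes one aryl group, from 3-(trifluoromethyl)phenyl to 4-chloro-3-(trifluoromethyl)phenyl. This puts chloro in place of hydrogen on an aromatic carbon, ortho to a trifluoromethyl group and para to a large group (chloro in place of hydrogen on an aromatic carbon).

Among the measured compounds shown here, no measured pair differs in one place, so the size of this step has no direct precedent. A small step toward lower numbers in this assay is expected, and compound 3 may well report only a limit too. Compound 1, at 23700 nM, shows that a number can be reached in this series. The expected change is an at least 1.3-fold lower number from compound 2 to compound 3 (0.11 log units; that floor lies within the scatter). For compound 3 the estimate is 38000 nM, with an expected range from 15000 nM to 70000 nM.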

Compound 3, concentration lethal to 50% of the cells: > 32500 nM
Compound 3: no number, only a limit (the forecaster's own chance of this, stated with the estimate: 50%); the middle value does not contradict the limit.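

Compound 3 gives > 32500 nM in this assay, which is a limit and not a number. Compound 2 also stands at a limit, so no step can be read from the pair compound 2 and compound 3. The compounds shown leave open whether chloro in place of hydrogen on an aromatic carbon changes the read-out at all.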